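Carbonyl substituent variation on the shared core: efficacy notes

This account rests on a few compounds, and the source may have more. Where it says the series, first, only, none or still open, it means among the compounds named here.

Measured so far:
Compound 1, `Cc1nc(S(C)(=O)=O)ccc1Oc1ncnc(OC2CCN(C(=O)O[C@@H](C)C(F)(F)F)CC2)c1F`, in a functional assay on isolated protein for inhibition of Glucose-dependent insulinotropic receptor (Rattus norvegicus), read by HTRF and cAMP accumulation (on this read-out lower numbers stand for smaller maximal responses and higher numbers for larger maximal responses), gives 80%.
Compound 2, `Cc1nc(S(C)(=O)=O)ccc1Oc1ncnc(OC2CCN(C(=O)C(F)(F)F)CC2)c1F`, in this assay gives 76%.
Compound 3, `Cc1nc(S(C)(=O)=O)ccc1Oc1ncnc(OC2CCN(C(=O)C3CCCC3)CC2)c1F`, in this assay gives 83%.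

All three compounds share one core and differ only in the group on the carbonyl carbon attached to the amide-type nitrogen in the ring. Compound 3 holds the highest of the three numbers, yet a number 3 percentage points higher from compound 1 to compound 3 (within the scatter) and a number 7 percentage points higher from compound 2 to compound 3 (within the scatter) both lie within the scatter, so no order among the three can be read from them. The remaining pair behaves the same way: a number 4 percentage points lower from compound 1 to compound 2 (within the scatter).

Compound 4, `Cc1nc(S(C)(=O)=O)ccc1Oc1ncnc(OC2CCN(C(=O)c3noc(C(C)C)n3)CC2)c1F`, is the next member. Relative to compound 3 the change is 5-isopropyl-1,2,4-oxadiazol-3-yl in place of cyclopentyl on a carbonyl carbon. Every measured step bears on this one, since each of them also exchanged the group on the carbonyl carbon, and none of them moved the maximal response beyond the scatter. The expectation is therefore that the largest response reached stays where the series sits, with no step beyond the scatter. The expected step is a number 3 percentage points lower from compound 3 to compound 4 (within the scatter). Compound 4 is estimated at 80%, with a range from 68% to 92%.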

Compound 4, largest response reached (reported as efficacy), in percent of the reference or control that the assay uses: 81%
Compound 4: middle estimate off by 1 percentage points, on the low side; the measured number falls inside the stated range.
By their numbers in this assay, from the lowest: compounds 2, 1, 4 and 3 (each within the scatter of the next).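

Placing 5-isopropyl-1,2,4-oxadiazol-3-yl on a carbonyl carbon brings a five-membered aromatic ring with 3 hetero atoms and 3 hydrogen-bond acceptors to a place that held a carbon-only ring with 0 hydrogen-bond acceptors in compound 3, and in this assay the result is a number 2 percentage points lower from compound 3 to compound 4 (within the scatter). The comparisons with the other two groups read the same way, with a number 5 percentage points higher from compound 2 to compound 4 (within the scatter) and a number 1 percentage points higher from compound 1 to compound 4 (within the scatter), so across the four compounds shown, this position accepts an aromatic ring with hetero atoms, and no step leaves the scatter. No available data explain this flat response.

As far as these compounds go, it remains open whether a carboxylic acid or a basic amine on the same carbonyl carbon would also leave the maximal response within the scatter of these four compounds. It is also open whether a methyl or a tert-butyl group in place of the isopropyl on the 1,2,4-oxadiazole ring would change the response in this assay, since the compounds shown carry only the one substituted ring of this kind.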